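Swapping the aniline ring on a quinazoline thioacetamide core

This account rests on a few compounds, and the source may have more. Where it says the series, first, only, none or still open, it means among the compounds named here.

Measured compounds:
- compound 1, `O=C(CSc1nc(Nc2ccccc2)c2ccccc2n1)Nc1cccc([N+](=O)[O-])c1`: 28100 nM
- compound 2, `C=CC(=O)Nc1cccc(NC(=O)CSc2nc(Nc3cccc(Cl)c3)c3ccccc3n2)c1`: 7830 nM

Both compounds were tested in a functional assay on MGC-803 cells (Homo sapiens) for inhibition, read by MTT assay, with a stated time of 72 h; on this read-out higher numbers stand for weaker inhibition and lower numbers for stronger inhibition. Compound 1 gives 28100 nM, while compound 2 gives 7830 nM. Of these two numbers, compound 2 has the lower one, and the gap between compound 2 and compound 1 lies beyond the usual scatter of repeated measurements, so compound 2 is the stronger inhibitor of the pair. For the measured compounds named here, the two compounds differ in more than one place, so no single structural step connects them.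

Compound 3, `C=CC(=O)Nc1cccc(NC(=O)CSc2nc(Nc3cc(OC)c(OC)c(OC)c3)c3ccccc3n2)c1`, keeps the shared core and the acrylamide-bearing side of compound 2 and changes only the group on the nitrogen on an aromatic ring: 3,4,5-trimethoxyphenyl in place of 3-chlorophenyl on a nitrogen on an aromatic ring. Going by the values given here, no measured pair shows the effect of this particular exchange. With only compound 2 as a reference, a small step in this assay is expected, if any, leaning toward a somewhat lower number but quite possibly within the scatter; the step from compound 2 to compound 3 is estimated at a 1.6-fold lower number from compound 2 to compound 3 (0.19 log units; within the scatter). Compound 3 is therefore expected to give about 5000 nM, within a range from 1200 nM to 20000 nM.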

Compound 3, half-maximal inhibitory concentration: > 50000 nM
Compound 3 ended at the assay's limit; the forecaster's own chance of this, stated with the estimate: 5%; middle value at least 10-fold (1.00 log units) away from the limit.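

The group on this nitrogen clearly matters: with everything else in compound 2 kept, replacing 3-chlorophenyl with 3,4,5-trimethoxyphenyl in this assay gives an at least 6.3-fold higher number from compound 2 to compound 3 (0.80 log units; beyond the scatter). For the compounds shown here, this is the first exchange that can be read as a single step, and it shows that an aromatic ring at this place does not by itself preserve the activity, since both groups contain one six-membered aromatic ring of carbon only. The value of compound 3, > 50000 nM, is a limit of the assay and not a number, so the step is only a minimum and the true size of the loss remains unknown: the limit of > 50000 nM in this assay, at which 1 of the 3 values shown sits.

The pair cannot show whether the loss comes from the removal of the chlorine, from the arrival of the three methoxy groups, or from one particular methoxy group among them. As far as these compounds go, that question stays open without a phenyl ring carrying a single methoxy group, or an unsubstituted phenyl ring, on this nitrogen with the acrylamide-bearing side of compound 2 kept in place.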